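Fluorine added to a hydrazone thiazole: small change expected

This account rests on a few compounds, and the source may have more. Where it says the series, first, only, none or still open, it means among the compounds named here.

Compounds measured so far:
- compound 1, `O=[N+]([O-])c1ccc(-c2csc(N/N=C\c3ccncc3)n2)cc1`: "not active" (no number reported)
- compound 2, `Fc1ccc(-c2csc(N/N=C\c3ccncc3)n2)cc1`: 40%

The two compounds share a core and differ only in the group on the outer ring of carbon atoms. In an in vitro assay on BTI-TN-5B1-4 cells for inhibition of Amine oxidase [flavin-containing] A (Homo sapiens), read by Amplex Red, with a stated time of 15 min, tested at 100 uM (on this read-out lower numbers stand for less inhibition and higher numbers for more inhibition at the one concentration tested (going by the name of the read-out)), compound 1 is reported as "not active" (no number reported), with no number given. In this assay, for the measured compounds named here, compound 2 gives 40%, which is the only actual number in this small set, so it stands as the sole point of reference.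

Compound 3, `Fc1ccc(-c2csc(N/N=C\c3ccncc3)n2)c(F)c1`, has not been measured. It differs from compound 2 by fluoro in place of hydrogen on an aromatic carbon. Going by the values given here, no step between two measured compounds is available to say how such a change tends to play out, so the expectation rests on compound 2 alone. A second fluoro group on the same ring is a small addition; with nothing to suggest otherwise, the step is expected to stay within the usual scatter, neither clearly up nor clearly down. Compound 3 is therefore estimated to reach 40% in this assay, within 20% to 60%, an expected step of no change at the digits printed from compound 2 to compound 3 (within the scatter).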

Compound 3, a percentage reported as inhibition, at one concentration (the size of the read-out at that concentration, not a potency): "not active" (no number reported)
Compound 3: no number reported, so the estimate cannot be set against anything.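

In this assay, for the compounds shown here, compound 3 gives "not active" (no number reported) and so no step from compound 2 can be read, since a number is needed on both sides. No measurement shown bears on the reason for this result. Left open is how far compound 3 truly lies from compound 2, which gives 40% in this assay.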